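Notes on an aryl-substituted acid series in a rat inhibition assay

A few compounds are considered here, and "the series" means these few. Any claim that something is new, unique, unknown or untested is made for them only; others in the source may bear on it.

Measured compounds:
compound 1, `CCCCOc1ccccc1-c1ncc(C(=O)O)c(=O)[nH]1`: 0.5 mg/kg
compound 2, `CSc1ccccc1-c1ncc(C(=O)O)c(=O)[nH]1`: > 20 mg/kg
compound 3, `CCOc1ccc(C(=O)O)cc1-c1ncc(C(=O)O)c(=O)[nH]1`: 25 mg/kg

In a functional assay on the whole organism (strain Sprague-Dawley) for inhibition, with Rattus norvegicus as the target, with a stated time of 10 min (on this read-out higher numbers stand for an effect only at larger amounts of compound and lower numbers for an effect already at smaller amounts), compound 1 gives 0.5 mg/kg. Compound 2 reaches only the limit of the assay, > 20 mg/kg, and no number is known for it. Compound 3 gives 25 mg/kg, the highest of the two numbers shown; its nearest neighbour is compound 1, a large gap beyond the scatter. Within the data shown here, the only step between measured compounds that differ in one place is an at least 40-fold higher number from compound 1 to compound 2 (1.60 log units; beyond the scatter), which concerns the alkoxy group, not the position changed here. One of the three values sits at the limit of > 20 mg/kg in this assay, at which 1 of the 3 values shown sits.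

Compound 4, `CCOc1ccc(S(=O)(=O)N(C)C(C)C)cc1-c1ncc(C(=O)O)c(=O)[nH]1`, is not yet measured in this assay. It differs from compound 3 by isopropyl(methyl)sulfamoyl in place of carboxy on an aromatic carbon. Among the measured compounds shown here, no measured step bears on this change, so its direction is open. For the measured compounds named here, compound 1, which carries no carboxy group, shows a much lower number than compound 3, but the two differ in two places and no single step can be drawn from them.

For compound 4 a value of 8 mg/kg is expected, with a range from 1 mg/kg to 40 mg/kg. This estimate means a step of a 3.1-fold lower number from compound 3 to compound 4 (0.49 log units; beyond the scatter), and it remains uncertain.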

Compound 4, dose for 50% inhibition: > 10 mg/kg
Compound 4: a limit, no number; the forecaster's own chance of this, stated with the estimate: 25%; middle value at least 1.2-fold (0.09 log units) from the limit.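

In compound 4 the result is a limit and not a number, so the step from compound 3 to compound 4 cannot be read: the limit of > 10 mg/kg in this assay, at which 1 of the 4 values shown sits.

The compounds shown leave open whether isopropyl(methyl)sulfamoyl in place of carboxy on an aromatic carbon raises or lowers the number in this assay, and by how much.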